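The source may report more compounds than this note shows. Statements on the series, on what has been measured and on what is new or still open speak of the compounds shown alone.

The series consists of four compounds built on a shared core: compound 1 (`Fc1ccccc1C1Cc2nccn2C1`), compound 2 (`c1ccc(C2Cc3nccn3C2)cc1`), compound 3 (`NC(=O)c1ccccc1C1Cc2nccn2C1`) and compound 4 (`N#Cc1ccccc1C1Cc2nccn2C1`). They were to be compared in an in vitro ADME assay on microsomes from liver (Homo sapiens) for metabolic stability; on this read-out lower numbers stand for slow clearance and higher numbers for fast clearance. In this assay, compound 1 stands at "not determined" (no result reported). Compound 3 stands at "not determined" (no result reported), so it offers no single number from which to start. Compound 2 is the only one of the three with a reported result, at 15 mL.min-1.g-1; < 7 mL.min-1.g-1 (2 entries), and these entries give no single number.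

The step from compound 3 to compound 4 places cyano in place of carbamoyl on an aromatic carbon. Among the measured compounds shown here, no measured step shows what such an exchange does, so no change beyond the usual scatter is expected in this assay, and no direction can be assigned. The expectation is anchored on compound 2, whose entries of 15 mL.min-1.g-1; < 7 mL.min-1.g-1 (2 entries) give no single number, and it therefore remains weak. In this assay, the estimated value for compound 4 is 10 mL.min-1.g-1, with an expected range from 5 mL.min-1.g-1 to 25 mL.min-1.g-1.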

Compound 4, intrinsic clearance in microsomes: < 7 mL.min-1.g-1
Compound 4 was reported as a limit (the forecaster's own chance of this, stated with the estimate: 35%); at least 1.4-fold (0.15 log units) between middle value and limit.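

In this assay compound 4 gives < 7 mL.min-1.g-1, which is a limit and not a number. Compound 3 offers no single number, so no step can be read between compound 3 and compound 4. The compounds shown leave open what cyano in place of carbamoyl on an aromatic carbon does to clearance in this assay.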